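Working notes: a selenium-to-sulfur swap in a cytotoxicity series

The compounds below may be only part of what the source reports. "The series", "measured", "known", "first", "only" and "open" are said of these compounds alone.

Compound 1 `CS/C(=N\C(=O)c1csc([N+](=O)[O-])c1)NC(=O)c1csc([N+](=O)[O-])c1` in a functional assay on K562 cells (Homo sapiens) for cytotoxicity, read by MTT assay, with a stated time of 72 h (on this read-out lower numbers stand for higher toxicity in this test and higher numbers for lower toxicity in this test), sits at the assay limit, > 100000 nM.
Compound 2 `O=C(/N=C(/NC(=O)c1cc(-c2ccccc2)nc2ccccc12)[Se]Cc1ccccc1)c1cc(-c2ccccc2)nc2ccccc12` gives 88900 nM in this assay.
Compound 3 `C[Se]/C(=N\C(=O)c1ccno1)NC(=O)c1ccno1` sits at the assay limit, > 100000 nM.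

Among the measured compounds shown here, compound 2 is therefore the only member with a number in this assay; the other two values are limits, as summarised by the limit of > 100000 nM in this assay, at which 2 of the 3 values shown sit. Compound 4 `CS/C(=N\C(=O)c1cc(-c2ccccc2)nc2ccccc12)NC(=O)c1cc(-c2ccccc2)nc2ccccc12` differs from compound 2 by a group of 2 heavy atoms (1 carbon, 1 sulfur; no ring) in place of a group of 8 heavy atoms (7 carbon, 1 selenium; one six-membered aromatic ring of carbon only), on a carbon with a double bond to nitrogen, in words a group of 2 heavy atoms (1 carbon, 1 sulfur; no ring) in place of a group of 8 heavy atoms (7 carbon, 1 selenium; one six-membered aromatic ring of carbon only), on a carbon with a double bond to nitrogen. For the measured compounds named here, no step between measured compounds exists for this change. Given that compound 1 and compound 3 sit at the limit (the limit of > 100000 nM in this assay, at which 2 of the 3 values shown sit), the estimated step from compound 2 to compound 4 in this assay is expected to go toward lower toxicity, a 1.3-fold higher number from compound 2 to compound 4 (0.13 log units; within the scatter). Compound 4 is expected to give about 120000 nM, within 50000 nM to 300000 nM.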

Compound 4, concentration lethal to 50% of the cells: > 100000 nM
Compound 4 was reported as a limit (the forecaster's own chance of this, stated with the estimate: 65%); the middle value does not contradict the limit.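

Among the compounds shown here, the change to methylsulfanyl, on a carbon with a double bond to nitrogen, gives the first step in this assay: an at least 1.1-fold higher number from compound 2 to compound 4 (0.05 log units; that floor lies within the scatter). Compound 4 gives a limit and not a number, so this floor is all that can be read of the change. The limit now covers most of the series: the limit of > 100000 nM in this assay, at which 3 of the 4 values shown sit.

Selenium gives way to sulfur as the group also shrinks, leaving open which of the two changes bears on the read-out. Also open, on these data alone, is how an amine or a longer alkyl chain on that carbon would read in this assay.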